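The source may hold more compounds than are shown below. What is called first, only, known or untested is meant among the compounds shown, and "the series" means these compounds.

Of the compounds shown here, two on the shared core have been tested so far in a functional assay on RAW264.7 cells (Mus musculus) for inhibition; on this read-out higher numbers stand for weaker inhibition and lower numbers for stronger inhibition. Compound 1 (`COc1cc(/C=C/C(=O)CC(=O)/C=C/c2ccc(OC(=O)c3ccccc3OC(=O)c3ccccc3O)c(OC)c2)ccc1O`) gives > 30000 nM, which is a limit of the assay and not a number. Compound 2 (`COc1cc(/C=C/C(=O)CC(=O)/C=C/c2ccc(OC(=O)c3ccccc3OC(C)=O)c(OC)c2)ccc1O`) gives > 30000 nM, which is also a limit, so its place on the scale is not known as a number. Compound 3 (`COc1cc(/C=C/C(=O)CC(=O)/C=C/c2ccc(OC(=O)c3ccccc3O)c(OC)c2)ccc1O`) differs from compound 2 in one place: hydrogen in place of acetyl on an oxygen on an aromatic ring. This is hydrogen in place of acetyl on an oxygen on an aromatic ring, so acetoxy becomes hydroxy. Going by the values given here, the only measured step is a step that the two limits leave unreadable from compound 1 to compound 2; it changes a different group and offers no size to carry over. Both compound 1 and compound 2 keep the expectation close to the limit because of the limit of > 30000 nM in this assay, at which 2 of the 2 values shown sit. Among the compounds with values here, a modest move towards stronger inhibition is expected, though no measured step sets its size, and the expected step is an at least 1.2-fold lower number from compound 2 to compound 3 (0.07 log units; that floor lies within the scatter). For compound 3 the estimate is 25000 nM, with an expected range from 8000 nM to 50000 nM.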

Compound 3, half-maximal inhibitory concentration: > 30000 nM
Compound 3 ended at the assay's limit; the forecaster's own chance of this, stated with the estimate: 55%; at least 1.2-fold (0.07 log units) between middle value and limit.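

No step among compound 1, compound 2 and compound 3 can be read, because all three end at a limit and not at a number: the limit of > 30000 nM in this assay, at which 3 of the 3 values shown sit.

The compounds shown leave open how strongly each one inhibits, and whether hydrogen, acetyl or (2-hydroxyphenyl)carbonyl on that oxygen changes inhibition at all.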